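Chloro for Methyl on the Side Ring: Expected Gain

The compounds below may be only part of what the source reports. "The series", "measured", "known", "first", "only" and "open" are said of these compounds alone.

Measured so far:
compound 1, `Cc1ccc(-n2cc(C(=O)Nc3cc(F)cc(F)c3)c(=O)c3ccc(N(C)C)nc32)cc1OCCCCCCC[N+]1(C)CCCC1`, gives 55.9% in an assay on LX2 cells for inhibition of COL1A1 promoter (Homo sapiens), read by a luciferase reporter, with a stated time of 24 h, tested at 50 uM; a higher number here means a stronger effect of the compound at the concentration tested, a lower number a weaker effect
compound 2, `CN(C)c1ccc2c(=O)c(C(=O)Nc3cc(F)cc(F)c3)cn(-c3ccc(Cl)c(OCCCCCCC[N+]4(C)CCCC4)c3)c2n1`, gives 76.1%
compound 3, `Cc1cc(-n2cc(C(=O)Nc3cc(F)cc(F)c3)c(=O)c3ccc(N(C)C)nc32)ccc1OCCCCCCC[N+]1(C)CCCCC1`, gives 54.4%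

Compound 2 differs from compound 1 by chloro in place of methyl on an aromatic carbon, and this change made a number 20.2 percentage points higher from compound 1 to compound 2 (beyond the scatter). Compound 3 and compound 1 differ in more than one place; the difference between the two cores is not broken down here. Compound 4, `CN(C)c1ccc2c(=O)c(C(=O)Nc3cc(F)cc(F)c3)cn(-c3ccc(OCCCCCCC[N+]4(C)CCCCC4)c(Cl)c3)c2n1`, has not yet been measured; it differs from compound 3 by chloro in place of methyl on an aromatic carbon. This is the same kind of change as that from compound 1 to compound 2, but not the same: in compound 2 the chloro sits ortho to a large group and para to a large group, in compound 4 ortho to a large group and meta to a large group. Within the data shown here, since the only measured example of this change is a number 20.2 percentage points higher from compound 1 to compound 2 (beyond the scatter), a gain of the same direction but somewhat smaller size is expected, a number 14.6 percentage points higher from compound 3 to compound 4 (beyond the scatter), the caution resting on the differing surroundings and on a single precedent. Compound 4 is therefore expected to give 69% in this assay, between 55% and 83%.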

Compound 4, a percentage reported as inhibition, at one concentration (the size of the read-out at that concentration, not a potency): "not active" (no number reported)
For compound 4 the study gives words and no number, so the estimate cannot be set against anything.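

Among these compounds, compound 4 is reported in this assay only in words, as not active, so no step from compound 3 to compound 4 can be read. The compounds shown leave open how large any effect of chloro in place of methyl is at this place on the ring. No measurement shown explains the result.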